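Amide replaces alkyl chain on the ring amine nitrogen

The compounds below may be only part of what the source reports. "The series", "measured", "known", "first", "only" and "open" are said of these compounds alone.

Three compounds with a shared core were tested in an in vitro functional assay on RBL cells for antagonist activity at C-C chemokine receptor type 8 (Homo sapiens), read by FLIPR and calcium flux; a higher number here means a weaker inhibitor, a lower number a stronger inhibitor. Compound 1 `COc1ccc2nccc(C3CN(C4CCN(Cc5cc6ccccc6o5)CC4)C(=O)O3)c2c1` gives 1260 nM. Compound 3 `COc1ccc2nccc(C3CN(C4CCN(CCCc5ccccc5)CC4)C(=O)O3)c2c1` gives 251 nM, the lowest of the two numbers; its nearest neighbour is compound 1, and the step of a 5.0-fold lower number from compound 1 to compound 3 (0.70 log units; beyond the scatter) lies beyond the scatter. Compound 2 `COc1ccc2nccc(C3CN(C4CCN(C)CC4)C(=O)O3)c2c1` gives only a limit of this assay, < 50200 nM. Because of the limit of < 50200 nM in this assay, at which 1 of the 3 values shown sits, the steps a step that the limit leaves unreadable from compound 1 to compound 2 and a step that the limit leaves unreadable from compound 2 to compound 3 cannot be sized.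

Compound 4 `COc1ccc2nccc(C3CN(C4CCN(C(=O)c5ccc(Cl)c(Cl)c5)CC4)C(=O)O3)c2c1` differs from compound 3 in one place: (3,4-dichlorophenyl)carbonyl in place of 3-phenylpropyl on an amine nitrogen in a ring. Among the compounds with values here, only one measured step bears on this nitrogen with a readable size, the exchange of one aromatic group for another in a 5.0-fold lower number from compound 1 to compound 3 (0.70 log units; beyond the scatter), which was modest. Within the data shown here, no measured step replaces a saturated chain by a carbonyl-linked group, so the direction of the new change is not read from the data, and the unreadable hydrogen step leaves wide room.

Compound 4 is therefore expected to give 3000 nM, with a wide range from 300 nM to 25000 nM. The step expected is a 12-fold higher number from compound 3 to compound 4 (1.08 log units; beyond the scatter), judged more likely to weaken than to strengthen inhibition.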

Compound 4, half-maximal inhibitory concentration: 6310 nM
Beside the measured number, compound 4's estimate is 2.1-fold (0.32 log units) below it, within the range that was stated.
By their numbers in this assay, from the lowest: compound 3; then compound 1; then compound 4.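

In this assay, compound 4 is the only compound shown that joins its group to this amine nitrogen in a ring through a carbonyl, and putting (3,4-dichlorophenyl)carbonyl in place of 3-phenylpropyl gives a 25-fold higher number from compound 3 to compound 4 (1.40 log units; beyond the scatter). The comparison with the benzofuran-bearing chain points the same way, with a 5.0-fold higher number from compound 1 to compound 4 (0.70 log units; beyond the scatter), so among the three compounds with readable numbers, the carbonyl-linked group gives the highest number and the weakest inhibition. The step from compound 2 to compound 4 cannot be read, as compound 2 gives a limit rather than a number: the limit of < 50200 nM in this assay, at which 1 of the 4 values shown sits.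

The compounds shown leave open whether the higher number follows from the carbonyl itself or from the two chlorine atoms on the aromatic ring, as the step changes both at once, along with the chain. An unsubstituted benzoyl group and a 3-(3,4-dichlorophenyl)propyl chain on the same nitrogen would separate these two changes, and a sulfonyl link in place of the carbonyl would show whether the loss extends beyond amides.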